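Following compound 2 from pyridin-3-yl to bromo

The compounds below may be only part of what the source reports. "The series", "measured", "known", "first", "only" and "open" are said of these compounds alone.

Values so far in a functional assay on HL-60 cells (Homo sapiens) for cytotoxicity, read by luminescence and CellTiter-Glo, with a stated time of 3 days; on this read-out lower numbers stand for stronger inhibition and higher numbers for weaker inhibition
compound 1 (`O=C(Nc1ccc(C(F)(F)F)cc1)c1cc(F)ccc1O`) gives 490 nM
compound 2 (`N#Cc1ccc(NC(=O)c2ccc(-c3cccnc3)cc2O)cc1`) gives 6660 nM
compound 3 (`N#Cc1ccc(NC(=O)c2cc(Br)c(-c3ccccc3)cc2O)cc1`) gives 700 nM

Compound 2 has the highest number of the three, and both other compounds lie below it by more than the scatter. Compound 4 (`N#Cc1ccc(NC(=O)c2ccc(Br)cc2O)cc1`) has not been measured yet. It has bromo in place of pyridin-3-yl on an aromatic carbon. Going by the values given here, no pair of measured compounds shows this change alone. Compound 3 also carries bromo and gives 700 nM in this assay, so a moderate fall beyond the scatter is expected, though this is weak evidence. The expected move is a 4.4-fold lower number from compound 2 to compound 4 (0.65 log units; beyond the scatter) in this assay, towards stronger inhibition. For compound 4 the estimated value is 1500 nM (expected range 450 nM to 5500 nM).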

Compound 4, half-maximal inhibitory concentration: 1210 nM
For compound 4 the middle estimate is 1.2-fold (0.09 log units) above the measured one, within the range that was stated.
By their numbers in this assay, from the lowest: compounds 1, 3 and 4 (each within the scatter of the next, the first and the last beyond it); then compound 2.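

In this assay, going by these compounds alone, the change from pyridin-3-yl to bromo on this aromatic carbon gives a 5.5-fold lower number from compound 2 to compound 4 (0.74 log units; beyond the scatter) and is the first direct reading at this position. A whole six-membered aromatic ring is therefore not needed here for this level of inhibition, and a single bromine atom gives the lower number. Nothing measured here explains the step. 

This rests on one pair of compounds with one shared core. From the compounds shown here alone, whether an amine, a methoxy group or chloro on this carbon would lower the number further stays open.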